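This account rests on a few compounds, and the source may have more. Where it says the series, first, only, none or still open, it means among the compounds named here.

Compound 1 `Cc1ccc(C(=O)NNC(=O)c2cccc(NS(=O)(=O)c3cnc(O)nc3O)c2)cc1`: > 20000 nM
Compound 2 `O=C(NNC(=O)c1ccccc1F)c1cccc(NS(=O)(=O)c2cnc(O)nc2O)c1`: 10800 nM

Going by the values given here, in a functional assay on OVCAR-3 cells (Homo sapiens) for antiproliferative activity, read by MTT assay, with a stated time of 24 h (a higher number here means a weaker inhibitor, a lower number a stronger inhibitor), compound 2 gives 10800 nM, the only exact number so far. Compound 1 reads > 20000 nM, which is a limit of the assay and not a number.

The compound still to be tested is compound 3 `O=C(NNC(=O)c1cccc(NS(=O)(=O)c2cnc(O)nc2O)c1)c1ccc(F)cc1`. It has 4-fluorophenyl in place of 2-fluorophenyl on a carbonyl carbon.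

Among the compounds with values here, one measured step bears on this change, and it alters the group at the same place: an at least 1.8-fold lower number from compound 1 to compound 2 (0.26 log units; that floor lies within the scatter). Since compound 1 carries 4-methylphenyl there, this is weak evidence, and it gives only a slight lean towards a higher number. The expected change is small, a 1.2-fold higher number from compound 2 to compound 3 (0.08 log units; within the scatter), and no step beyond the scatter is expected. For compound 3 the estimate is 13000 nM, with an expected range from 6000 nM to 24000 nM.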

Compound 3, half-maximal inhibitory concentration: > 20000 nM
Compound 3 ended at the assay's limit; the forecaster's own chance of this, stated with the estimate: 30%; middle value at least 1.5-fold (0.18 log units) from the limit.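

Replacing 2-fluorophenyl with 4-fluorophenyl on the carbonyl carbon keeps the same atoms, joined differently, and gives an at least 1.8-fold higher number from compound 2 to compound 3 (0.26 log units; that floor lies within the scatter) in this assay. The full size of this step cannot be read, because the reading of compound 3 is cut off at a limit: the limit of > 20000 nM in this assay, at which 2 of the 3 values shown sit.

Compound 3 now sits at the same limit as compound 1, so the step between those two cannot be read, and among these three compounds only the one with 2-fluorophenyl gives an exact number.

With a floor inside the scatter, these data cannot establish that the fluorine's place on the ring matters. Going by these compounds, how 3-fluorophenyl, unsubstituted phenyl or 2-chlorophenyl would read at this place remains open, as does whether anything beyond fluorine would give an exact number here.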